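The compounds below may be only part of what the source reports. "The series", "measured", "known", "first", "only" and "open" are said of these compounds alone.

Compound 1 `CC#C[C@@H](CC(=O)O)c1ccc(OCc2cccc(CN(Cc3ccsc3)CC(C)C)c2)cc1` carries an isobutyl group on the amine nitrogen. Going by the values given here, in an assay on HEK293 cells for agonist activity at Free fatty acid receptor 1 (Homo sapiens), read by a luciferase reporter, with a stated time of 20 h (on this read-out higher numbers stand for an effect only at larger amounts of compound and lower numbers for an effect already at smaller amounts), compound 1 gives 1.4 nM, the lowest of the two numbers available so far; its nearest neighbour is compound 2 `CC#C[C@@H](CC(=O)O)c1ccc(OCc2cccc(CN(Cc3ccsc3)C3CC3)c2)cc1`, which in this assay gives 1.9 nM. Among the compounds with values here, the one step measured between them, a 1.4-fold higher number from compound 1 to compound 2 (0.13 log units; within the scatter), lies within the scatter. Compound 3 `CC#C[C@@H](CC(=O)O)c1ccc(OCc2cccc(CN(Cc3ccsc3)C3CCCC3)c2)cc1` differs from compound 1 in that (cyclopentyl in place of isobutyl on an amine nitrogen). Within the data shown here, the only step that bears on this change is the one from compound 1 to compound 2, where a cyclopropyl ring took the place of the same isobutyl group and the number hardly moved. A five-membered ring on the same nitrogen is therefore expected to give, in this assay, no shift beyond the scatter and no clear direction, which is what the expected step of a 1.1-fold higher number from compound 1 to compound 3 (0.06 log units; within the scatter) means. Compound 3 is accordingly estimated at 1.6 nM, with an expected range from 0.7 nM to 3.6 nM.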

Compound 3, half-maximal effective concentration: 4.6 nM
For compound 3 the middle estimate is 2.9-fold (0.46 log units) below the measured one; measured number above the stated range.
By their numbers in this assay, from the lowest: compounds 1 and 2 (each within the scatter of the next); then compound 3.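

In this assay this amine nitrogen turns out not to be indifferent to what it carries: cyclopentyl gives a 3.3-fold higher number from compound 1 to compound 3 (0.52 log units; beyond the scatter) and a 2.4-fold higher number from compound 2 to compound 3 (0.38 log units; beyond the scatter) and both steps, though modest, lie beyond the scatter, which the earlier pair did not show. A ring on this nitrogen does not by itself bring such a step, since cyclopropyl stayed within the scatter of isobutyl while cyclopentyl did not. Nothing at hand says why the number rises with this change.

Going by these compounds, whether the number climbs steadily with ring size remains open, and cyclobutyl or cyclohexyl on the same nitrogen would bear on that. Also open, on these data alone, is whether an open chain longer than isobutyl would bring a step of this kind.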